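From thiophen-3-yl to 1-benzofuran-2-yl on the shared core

A few compounds are considered here, and "the series" means these few. Any claim that something is new, unique, unknown or untested is made for them only; others in the source may bear on it.

Measured in a functional assay on HCT-116 cells (Homo sapiens), read by MTT assay, with a stated time of 72 h; on this read-out lower numbers stand for stronger inhibition and higher numbers for weaker inhibition
Compound 1 `Nc1nc(N)c2c(-c3cccs3)cn([C@@H]3O[C@H](CO)[C@@H](O)[C@H]3O)c2n1` gives > 20000 nM as a limit
Compound 2 `Nc1nc(N)c2c(-c3ccsc3)cn([C@@H]3O[C@H](CO)[C@@H](O)[C@H]3O)c2n1` gives > 20000 nM as a limit

Compound 2 has no number in this assay and stands only at the limit > 20000 nM on this scale. Among the compounds with values here, the series so far is the limit of > 20000 nM in this assay, at which 2 of the 2 values shown sit, and offers no graded value.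

Compound 3 `Nc1nc(N)c2c(-c3cc4ccccc4o3)cn([C@@H]3O[C@H](CO)[C@@H](O)[C@H]3O)c2n1` comes from compound 2 by a single change 1-benzofuran-2-yl in place of thiophen-3-yl on an aromatic carbon with 1-benzofuran-2-yl in place of thiophen-3-yl on an aromatic carbon. The entering group adds one six-membered aromatic ring of carbon only.

Within the data shown here, the one measured step that bears on this is a step that the two limits leave unreadable from compound 1 to compound 2 and it gives no size to carry over. No direction can be drawn from it either.

The only anchor is the limit of compound 2 at > 20000 nM and so no readable shift is expected. The estimated step is a number no higher from compound 2 to compound 3 (the limit leaves the size open) and a limit is the expected outcome. For compound 3 the estimated value is 20000 nM and it is expected to fall from 6000 nM to 40000 nM in this assay here.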

Compound 3, half-maximal inhibitory concentration: 14000 nM
The estimate for compound 3 lay 1.4-fold (0.15 log units) above the measured number, within the range that was stated.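

In this assay compound 3 gives 14000 nM, the only graded number among the compounds shown, so this position on the shared core can carry a group that gives a value inside the measured range, here 1-benzofuran-2-yl with its six-membered aromatic ring of carbon only. On these data alone, measured against two limits, the change reads as an at least 1.4-fold lower number from compound 2 to compound 3 (0.15 log units; that floor lies within the scatter) and as an at least 1.4-fold lower number from compound 1 to compound 3 (0.15 log units; that floor lies within the scatter), so each step is only a floor and its true size remains unknown. The step from compound 1 to compound 2 cannot be read, and most of the series still stands at a limit rather than at a number: the limit of > 20000 nM in this assay, at which 2 of the 3 values shown sit.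

The compounds shown do not separate the added carbon ring from the exchange of ring sulfur for ring oxygen as the change tied to the graded value of compound 3. Also open, as far as these compounds go, is how a plain phenyl ring, or an aromatic ring carrying an amine or a carboxylic acid, would read at this position.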